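The compounds below may be only part of what the source reports. "The series", "measured", "known", "first", "only" and "open" are said of these compounds alone.

compound 1 `CC(C)N(C)c1nc(Cc2c(F)cccc2F)cc(=O)[nH]1`: 85000 nM
compound 2 `O=c1cc(Cc2c(F)cccc2F)nc(N2CCCCC2)[nH]1`: > 82000 nM, a limit
compound 3 `CC1CCN(c2nc(Cc3c(F)cccc3F)cc(=O)[nH]2)CC1`: > 78000 nM, a limit

All three values come from an ADME assay on MT4 cells (Homo sapiens) for cytotoxicity, read by MTT assay, with a stated time of 4 days; on this read-out higher numbers stand for lower toxicity in this test and lower numbers for higher toxicity in this test. Compound 3 has no number there, only the limit > 78000 nM. Compound 2 also has only a limit, > 82000 nM. Going by the values given here, compound 1 is the one compound with a number, 85000 nM.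

The next change gives compound 4 `O=c1cc(Cc2c(F)cccc2F)nc(-n2cccc2)[nH]1`, with 1H-pyrrol-1-yl in place of 4-methylpiperidin-1-yl on an aromatic carbon, between two ring nitrogen atoms: 1H-pyrrol-1-yl in place of 4-methylpiperidin-1-yl on an aromatic carbon.

Among the compounds with values here, three measured steps bear on this group: a step that the limit leaves unreadable from compound 1 to compound 2, a step that the limit leaves unreadable from compound 1 to compound 3 and a step that the two limits leave unreadable from compound 2 to compound 3. None has a readable size, so they set neither a size nor a direction for the new exchange. Within the data shown here, none of the measured compounds carries 1H-pyrrol-1-yl or any other aromatic ring in this place.

The expectation therefore rests only on the general level of the series in this assay, with some allowance for a shift towards higher toxicity in this test. A limit rather than a number is also a likely outcome. The expected change is an at least 1.1-fold lower number from compound 3 to compound 4 (0.04 log units; that floor lies within the scatter), and no large step is expected. For compound 4 the estimated value is 70000 nM, with an expected range from 25000 nM to 90000 nM.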

Compound 4, half-maximal cytotoxic concentration: > 87000 nM
Compound 4: a limit, no number; the forecaster's own chance of this, stated with the estimate: 55%; at least 1.2-fold (0.09 log units) between middle value and limit.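

With compound 4, an aromatic ring stands for the first time among the compounds shown on the aromatic carbon between two ring nitrogen atoms, and the result in this assay is again only a limit: the limit of > 87000 nM in this assay, at which 1 of the 4 values shown sits. Going by these compounds alone, the one step that can be read is an at least 1.0-fold higher number from compound 1 to compound 4 (0.01 log units; that floor lies within the scatter), so exchanging isopropyl(methyl)amino for 1H-pyrrol-1-yl gives no sign of higher toxicity in this test. The steps to compound 4 from compound 2 and from compound 3 cannot be read, but the 1H-pyrrol-1-yl compound joins the piperidin-1-yl and 4-methylpiperidin-1-yl compounds in giving only a limit.

The numbers behind the limits of compound 2, compound 3 and compound 4 remain open, so no order among these three can be given. Also open, as far as these compounds go, is how this place responds to a free amino group, a morpholin-4-yl ring, a phenyl ring or a carboxylic acid.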